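The compounds below may be only part of what the source reports. "The series", "measured", "known", "first", "only" and "open" are said of these compounds alone.

Measured compounds:
compound 1, `CCCCCCCCS(=O)(=O)Nc1cc(-c2ccc(CCCC)cc2)ccc1C(=O)O`: 15700 nM
compound 2, `CCCCCCCCS(=O)(=O)Nc1cc(-c2ccc(-c3ccccc3)cc2)ccc1C(=O)O`: 13500 nM
compound 3, `CCCCCCCCS(=O)(=O)Nc1ccc(C(=O)c2ccccc2OC)cc1C(=O)O`: 59200 nM

In an assay on mitochondria (strain BALB/c) for inhibition of glycerol-3-phosphate acyltransferase 1, mitochondrial (Mus musculus), read by scintillation counting, with a stated time of 10 min (a higher number here means a weaker inhibitor, a lower number a stronger inhibitor), compound 1 stands second highest of the three numbers. Its nearest neighbour is compound 2, a 1.2-fold lower number from compound 1 to compound 2 (0.07 log units; within the scatter). Within the data shown here, compound 3 is furthest off, with 59200 nM against 15700 nM for compound 1; no single-place step links them.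

Compound 4, `CCCCCCCCS(=O)(=O)Nc1cc(/C=C/c2ccccc2)ccc1C(=O)O`, is not yet measured. It differs from compound 1 in one place: 2-phenylethenyl in place of 4-butylphenyl on an aromatic carbon. Among the measured compounds shown here, the only step that bears on it is the exchange of the distal group at this position, a 1.2-fold lower number from compound 1 to compound 2 (0.07 log units; within the scatter), which stayed within the scatter. A step of similar size is therefore expected for compound 4, with no clear direction beyond the scatter, a 1.1-fold higher number from compound 1 to compound 4 (0.06 log units; within the scatter). The estimate for compound 4 in this assay is 18000 nM, range 7000 nM to 45000 nM.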

Compound 4, half-maximal inhibitory concentration: 38000 nM
For compound 4 the middle estimate is 2.1-fold (0.32 log units) below the measured one; measured number inside the range.
By their numbers in this assay, from the lowest: compounds 2 and 1 (each within the scatter of the next); then compounds 4 and 3 (each within the scatter of the next).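

In this assay, the position on the aromatic carbon para to the carboxy group does respond to the group it carries: 2-phenylethenyl in place of 4-butylphenyl gives a 2.4-fold higher number from compound 1 to compound 4 (0.38 log units; beyond the scatter), a modest step but beyond the scatter, unlike a 1.2-fold lower number from compound 1 to compound 2 (0.07 log units; within the scatter). No measured information bears on the cause of this step.

As far as these compounds go, compound 4 changes the double bond, the butyl group and the heavy-atom count together, so their separate contributions remain open. From the compounds shown here alone, whether a saturated 2-phenylethyl group at this position would match compound 1 or compound 4 also remains open.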